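A few compounds are considered here, and "the series" means these few. Any claim that something is new, unique, unknown or untested is made for them only; others in the source may bear on it.

Of the compounds shown here, three have been tested in an ADME assay on HepG2 cells (Homo sapiens) for cytotoxicity, read by MTT assay, with a stated time of 24 h (on this read-out lower numbers stand for higher toxicity in this test and higher numbers for lower toxicity in this test), and none has yet given a number. Compound 3 `CC1Cn2c(nc([N+](=O)[O-])c2-c2ccccc2)O1` stands at > 500000 nM in that test, which is a limit of the assay. Compound 1 `CC1Cn2c(nc([N+](=O)[O-])c2-c2ccc(Cl)cc2)O1` stands at > 140000 nM as a limit too. Compound 2 `Cc1ccc(-c2c([N+](=O)[O-])nc3n2CC(C)O3)cc1` stands at > 125000 nM and this is also a limit.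

Compound 4 `CC1Cn2c(nc([N+](=O)[O-])c2-c2ccc(OC(F)(F)F)cc2)O1` follows from compound 3 by one change trifluoromethoxy in place of hydrogen on an aromatic carbon with trifluoromethoxy in place of hydrogen on an aromatic carbon, para to a large group. The measured steps that bear on it are the exchanges of chloro and of methyl for hydrogen on an aromatic carbon. Yet a step that the two limits leave unreadable from compound 1 to compound 3 and a step that the two limits leave unreadable from compound 2 to compound 3 have no readable size, and neither has a step that the two limits leave unreadable from compound 1 to compound 2 among the substituted pair. No measured size can therefore be carried over to this change.

The expectation leans on compound 1 with its limit of > 140000 nM as the closest substituted case. The estimated change is an at least 3.8-fold lower number from compound 3 to compound 4 (0.58 log units; beyond the scatter) in this assay and it is expected, weakly, towards lower numbers. For compound 4 the estimate is 130000 nM with an expected range from 40000 nM to 400000 nM and a report as a limit is the likelier outcome.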

Compound 4, half-maximal cytotoxic concentration: > 184000 nM
Compound 4 ended at the assay's limit; the forecaster's own chance of this, stated with the estimate: 75%; at least 1.4-fold (0.15 log units) between middle value and limit.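

In this assay compound 4 gives > 184000 nM, which is a limit of the assay and not a number. Going by these compounds alone, compound 1, compound 2 and compound 3 also stand at limits, and no step linking compound 4 to any of them can be read. What the compounds shown leave open is any order among the four and the size of any substituent step.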